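The source may report more compounds than this note shows. Statements on the series, on what has been measured and on what is new or still open speak of the compounds shown alone.

Series notes. In a functional assay on HO8910 cells (Homo sapiens) for inhibition, read by MTT assay, with a stated time of 24 h, tested at 10 ug/mL (a lower number here means less inhibition of growth, a higher number more inhibition of growth at the concentration tested), compound 1 (`O=C(O)CCCCC(CCSC(=O)c1ccccc1)SC(=O)c1ccccc1`) is reported as "not active" (no number reported), so it stands without a single number and offers only a qualitative starting point. Two related amides do have numbers. Compound 2 (`O=C(CCCCC1CCSS1)Nc1ccc(OC(F)(F)F)cc1`) gives 8.57% and compound 3 (`CC(=O)SCCC(CCCCC(=O)Nc1ccc(Cl)cc1)SC(C)=O`) gives 1.47%, and these two values lie within the usual scatter of each other. Both sit low on the percent scale at the single concentration tested.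

Compound 4 (`O=C(CCCCC(CCSC(=O)c1ccccc1)SC(=O)c1ccccc1)Nc1ccc(Cl)cc1`) has not yet been measured. Its difference from the core of compound 1 is (4-chlorophenyl)amino in place of hydroxy on a carbonyl carbon. Compound 3 carries the same (4-chlorophenyl)amino group and gives only 1.47%, which argues against expecting a large gain from this change alone. Going by the values given here, no measured pair isolates this change, and the lack of a number for compound 1 means the step cannot be computed. The step in this assay is expected to be small, upward if it shows at all, and quite possibly none beyond the scatter.

For compound 4 the estimated growth inhibition is 7%, with an expected range from 0% to 22%.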

Compound 4, percent growth inhibition at one concentration: "not active" (no number reported)
Compound 4: no number reported; the estimate stays without a comparison.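

In this assay compound 1 gives "not active" (no number reported) and compound 4 gives "not active" (no number reported) with no number for either, so no step can be read between them. No evidence bears on this result. The compounds shown leave open whether (4-chlorophenyl)amino in place of hydroxy on a carbonyl carbon changes growth inhibition at all.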